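Urea series: expected step from compound 3 to compound 4

A few compounds are considered here, and "the series" means these few. Any claim that something is new, unique, unknown or untested is made for them only; others in the source may bear on it.

Going by the values given here, compound 3 `O=C(Nc1ccccc1)Nc1nc(Nc2ccc(Cl)cc2)cc(Sc2c[nH]c3ccccc23)n1` is the only member of the set that returns a number: in a functional assay on A549 cells (Homo sapiens) for inhibition, with a stated time of 72 h (a lower number here means a stronger inhibitor, a higher number a weaker inhibitor), compound 3 gives 48400 nM. For compound 1 `O=C(Nc1ccccc1)Nc1nc(NC2CC2)cc(Sc2c[nH]c3ccccc23)n1` the assay reports a limit, > 50000 nM, and no number. For compound 2 `O=C(Nc1ccccc1)Nc1nc(Sc2c[nH]c3ccccc23)cc(N2CCN(Cc3ccccc3)CC2)n1` the assay likewise reports only the limit > 50000 nM. Among the compounds with values here, the single measured step, an at least 1.0-fold lower number from compound 1 to compound 3 (0.01 log units; that floor lies within the scatter), is read against the limit of > 50000 nM in this assay, at which 2 of the 3 values shown sit, and shows only that compound 3 sits where the values of the series stop.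

Compound 4 `O=C(Nc1ccccc1)Nc1nc(Sc2c[nH]c3ccccc23)cc(N2CCN(c3ccccn3)CC2)n1` differs from compound 3 by 4-(pyridin-2-yl)piperazin-1-yl in place of (4-chlorophenyl)amino on an aromatic carbon. Within the data shown here, no measured step covers this exchange. The step of an at least 1.0-fold lower number from compound 1 to compound 3 (0.01 log units; that floor lies within the scatter) concerns the same carbon but a different group and is within the scatter. Compound 2 carries a substituted piperazinyl group on the same carbon and returns only the limit > 50000 nM. Compound 4 is therefore expected near 50000 nM, between 20000 nM and 150000 nM, with a good chance that only a limit is reported. The expected step is a 1.0-fold higher number from compound 3 to compound 4 (0.01 log units; within the scatter), none beyond the scatter.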

Compound 4, half-maximal inhibitory concentration: 30300 nM
Compound 4: the middle estimate sits 1.7-fold (0.22 log units) above what was measured; low and high end bracket the measured number.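

In this assay, compound 4 shows that a piperazinyl group on this carbon can return a number rather than a limit, but a 1.6-fold lower number from compound 3 to compound 4 (0.20 log units; within the scatter), so 4-(pyridin-2-yl)piperazin-1-yl and (4-chlorophenyl)amino cannot be told apart here. Within the piperazine series, the change on the ring nitrogen gives an at least 1.6-fold lower number from compound 2 to compound 4 (0.21 log units; that floor lies within the scatter), and the exchange for cyclopropylamino gives an at least 1.6-fold lower number from compound 1 to compound 4 (0.21 log units; that floor lies within the scatter), so neither comparison establishes a real change. All of these steps stay close to the point where the values of the series stop: the limit of > 50000 nM in this assay, at which 2 of the 4 values shown sit.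

From the compounds shown here alone, it remains open whether any group on this carbon can move the number beyond the scatter, such as morpholine or an unsubstituted piperazine. Going by these compounds, the effect of changes to the (phenylcarbamoyl)amino and (1H-indol-3-yl)sulfanyl groups, which are the same in all four compounds, also remains open.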